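Replacing chloro with trifluoromethyl in compound 2

This account rests on a few compounds, and the source may have more. Where it says the series, first, only, none or still open, it means among the compounds named here.

In a functional assay on THP-1 cells (Homo sapiens) for cytotoxicity, read by MTT assay, with a stated time of 24 h (on this read-out lower numbers stand for stronger inhibition and higher numbers for weaker inhibition), compound 1 (`CN1C/C(=C\c2ccc(F)cc2)C(=O)/C(=C/c2cccc([N+](=O)[O-])c2)C1`) gives 7160 nM and compound 2 (`CN1C/C(=C\c2ccc(Cl)cc2)C(=O)/C(=C/c2cccc([N+](=O)[O-])c2)C1`) gives 7870 nM. Within the data shown here, compound 2 therefore stands level with compound 1, the only other measured compound, within the scatter. Compound 3 (`CN1C/C(=C\c2ccc(C(F)(F)F)cc2)C(=O)/C(=C/c2cccc([N+](=O)[O-])c2)C1`) has not yet been measured. It carries trifluoromethyl in place of chloro on an aromatic carbon, para to a large group: trifluoromethyl in place of chloro on an aromatic carbon. Among the measured compounds shown here, one measured step bears on this change, with chloro in place of fluoro on an aromatic carbon: a 1.1-fold higher number from compound 1 to compound 2 (0.04 log units; within the scatter). For the measured compounds named here, that step lies within the scatter, but it is a single pair, and no measured compound carries trifluoromethyl. No step beyond the scatter is therefore expected in this assay, and the range is kept wide. The expected change is a 1.1-fold lower number from compound 2 to compound 3 (0.05 log units; within the scatter). For compound 3 the estimated value is 7000 nM, with an expected range of 3500 nM to 14000 nM.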

Compound 3, half-maximal inhibitory concentration: 970 nM
Estimate against measurement, compound 3: 7.2-fold (0.86 log units) above; the whole stated range lies above it.
By their numbers in this assay, from the lowest: compound 3; then compounds 1 and 2 (each within the scatter of the next).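

In this assay, the place on the aromatic ring para to a large group proves responsive to its substituent: trifluoromethyl gives stronger inhibition than chloro (an 8.1-fold lower number from compound 2 to compound 3 (0.91 log units; beyond the scatter)) and than fluoro (a 7.4-fold lower number from compound 1 to compound 3 (0.87 log units; beyond the scatter)), whereas the exchange of the two halogens gave only a 1.1-fold higher number from compound 1 to compound 2 (0.04 log units; within the scatter). The level values of compound 1 and compound 2 therefore do not mean that this place tolerates any change without effect, and among these three compounds, only trifluoromethyl stands apart. Nothing at hand accounts for the size of this step.

Still open, as far as these compounds go, is whether trifluoromethyl is a singular case at this place or whether other groups, such as a nitrile, a methoxy group, an amine or a carboxylic acid, would give similarly low numbers. Also open, from the compounds shown here alone, is whether the step keeps its size when the other aromatic ring of the shared core carries a different substituent.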